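Three nitroaryl analogues and one ring change

The source may hold more compounds than are shown below. What is called first, only, known or untested is meant among the compounds shown, and "the series" means these compounds.

Three compounds share one core, differing only in the nitroaryl group on the amine nitrogen and, in one case, in the core itself. Compound 1 `CCOC(=O)C1=C(C)NC(=S)NC1c1cn(C(=O)CNc2ccc([N+](=O)[O-])c(Cl)c2)c2ccccc12` gives 50 ug/mL in a functional assay on MCF7 cells (Homo sapiens) for cytotoxicity, read by MTT assay, with a stated time of 72 h (a higher number here means a weaker inhibitor, a lower number a stronger inhibitor), compound 2 `CCOC(=O)C1=C(C)NC(=O)NC1c1cn(C(=O)CNc2ccc([N+](=O)[O-])cc2Cl)c2ccccc12` gives 50 ug/mL, and compound 3 `CCOC(=O)C1=C(C)NC(=S)NC1c1cn(C(=O)CNc2ccc([N+](=O)[O-])cc2C)c2ccccc12` gives 48 ug/mL. The three numbers sit within the scatter of one another, so compound 3 stands nowhere apart from the others. Among the measured compounds shown here, the one step between compounds differing in a single place, a 1.0-fold lower number from compound 1 to compound 3 (0.02 log units; within the scatter), was itself within the scatter.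

Compound 4 `CCOC(=O)C1=C(C)NC(=S)NC1c1cn(C(=O)CNc2cccc([N+](=O)[O-])c2)c2ccccc12` has 3-nitrophenyl in place of 2-methyl-4-nitrophenyl on an amine nitrogen. For the measured compounds named here, the only step that bears on this is the exchange of one nitroaryl group for another, which left the number unchanged within the scatter, and nothing in the data distinguishes compound 2 either. The step from compound 3 to compound 4 is therefore expected to show no change beyond the scatter, no change at the digits printed from compound 3 to compound 4 (within the scatter). Compound 4 is estimated at 48 ug/mL, with a range from 28 ug/mL to 85 ug/mL.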

Compound 4, half-maximal inhibitory concentration: > 1000 ug/mL
Compound 4 gave a limit, no number; the forecaster's own chance of this, stated with the estimate: 15%; at least 20-fold (1.31 log units) between middle value and limit.
By their numbers in this assay, from the lowest: compounds 3, 1 and 2 (each within the scatter of the next). At a limit, above all of these: compound 4.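

In this assay, the result for compound 4 is a limit and not a number: the limit of > 1000 ug/mL in this assay, at which 1 of the 4 values shown sits.

The exchange of 3-chloro-4-nitrophenyl for 2-methyl-4-nitrophenyl had left the number within the scatter, yet the aryl group on this amine nitrogen proves far from interchangeable. Placing 3-nitrophenyl there brings an at least 20-fold higher number from compound 3 to compound 4 (1.31 log units; beyond the scatter), and the same group brings an at least 20-fold higher number from compound 1 to compound 4 (1.30 log units; beyond the scatter). Thus, a change at this position can matter strongly in this assay, even though the earlier step showed no such effect.

Compared with 2-methyl-4-nitrophenyl, 3-nitrophenyl differs in both the methyl group and the place of the nitro group, so the compounds shown cannot separate the two. A plain 4-nitrophenyl group on the same amine nitrogen would address that question, while an aminophenyl group would test whether the nitro group matters at all.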